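This account rests on a few compounds, and the source may have more. Where it says the series, first, only, none or still open, it means among the compounds named here.

Measured so far:
- compound 1 `Cc1ccc(C2CNN=C2S(=O)(=O)CC2=NCCS2)cc1`: 43.1%
- compound 2 `O=S(=O)(CC1=NCCS1)c1c(-c2ccccc2)noc1-c1ccccc1`: "not active" (no number reported)
- compound 3 `Cc1ccc(C2CNN=C2S(=O)(=O)CC2=NCCO2)cc1`: 45.9%

All values come from a functional assay, read by Griess assay, with a stated time of 150 min, tested at 50 ug/mL; on this read-out higher numbers stand for a stronger effect at the one concentration tested and lower numbers for a weaker effect. Compound 1 gives 43.1% and compound 3 gives 45.9%; the two are within the scatter of each other, so nothing can be said of an order between them. Compound 2 is reported as "not active" (no number reported), with no number attached. Compound 1 and compound 2 share no single counted change; the difference between the two cores is not broken down here.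

The change from compound 1 to compound 3 is a group of 5 heavy atoms (3 carbon, 1 nitrogen, 1 oxygen; one five-membered non-aromatic ring with 2 hetero atoms) in place of a group of 5 heavy atoms (3 carbon, 1 nitrogen, 1 sulfur; one five-membered non-aromatic ring with 2 hetero atoms), on a saturated chain carbon bound to a sulfonyl sulfur. It made a step of a number 2.8 percentage points higher from compound 1 to compound 3 (within the scatter) in this assay. The same change is made from compound 2 to compound 4 `O=S(=O)(CC1=NCCO1)c1c(-c2ccccc2)noc1-c1ccccc1`, which is not yet measured: a group of 5 heavy atoms (3 carbon, 1 nitrogen, 1 oxygen; one five-membered non-aromatic ring with 2 hetero atoms) in place of a group of 5 heavy atoms (3 carbon, 1 nitrogen, 1 sulfur; one five-membered non-aromatic ring with 2 hetero atoms), on a saturated chain carbon bound to a sulfonyl sulfur. The place is the same in both pairs, so this is the same change made once more, on the other core.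

Within the data shown here, the one measured instance of this change rests on compound 1 and compound 3 and, because a number 2.8 percentage points higher from compound 1 to compound 3 (within the scatter) lies within the scatter, it gives no ground to expect compound 4 to move away from where compound 2 stands. Compound 2 is reported as "not active" (no number reported), so the likeliest outcome for compound 4 is again a report of no activity, or a small number. Compound 4 is expected to give 10% in this assay, with a range from 0% to 25%. This estimate rests on one pair only and carries little weight.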

Compound 4, a percentage reported as activity, at one concentration (the size of the read-out at that concentration, not a potency): 56.7%
Estimate against measurement, compound 4: 46.7 percentage points below; the measured number lies above the stated range.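

In this assay, among these compounds, compound 4 gives 56.7% against a bare report of "not active" for compound 2, so no step between the two can be read. No data shown bear on this result. The compounds shown leave open how large this ring exchange is on the core of compound 2, and whether it matches the exchange on the core of compound 1.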